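The source may report more compounds than this note shows. Statements on the series, on what has been measured and on what is new or still open speak of the compounds shown alone.

Among the three compounds measured in a functional assay on SK-OV-3 cells (Homo sapiens) for cytotoxicity, read by MTT assay, with a stated time of 24 h (a lower number here means a stronger inhibitor, a higher number a weaker inhibitor), compound 3 `COc1ccc(S(=O)(=O)Nc2nc(Cl)nc3cc(OC)c(OC)cc23)cc1C` stands highest: compound 3 gives 68.1 ug/mL, compound 2 `COc1cc2nc(N3CCCC3)nc(NS(=O)(=O)C3CC3)c2cc1OC` gives 17.6 ug/mL, and compound 1 `COc1cc2nc(Cl)nc(NS(=O)(=O)c3ccccc3)c2cc1OC` gives 9.23 ug/mL. Compound 4 `COc1cc2nc(Cl)nc(NS(=O)(=O)c3cccs3)c2cc1OC` differs from compound 3 in one place, (thiophen-2-yl in place of 4-methoxy-3-methylphenyl on a sulfonyl sulfur). For the measured compounds named here, only one measured step bears on this position: a 7.4-fold higher number from compound 1 to compound 3 (0.87 log units; beyond the scatter), which came from putting 4-methoxy-3-methylphenyl in place of phenyl on the sulfonyl sulfur. Thiophen-2-yl, like phenyl, is a single aromatic ring of five or six atoms without the added methoxy and methyl groups, so the change from compound 3 to compound 4 is expected to undo much of that rise and give a lower number, a 4.9-fold lower number from compound 3 to compound 4 (0.69 log units; beyond the scatter). Compound 4 is therefore estimated at about 14 ug/mL, within a range from 5 ug/mL to 40 ug/mL.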

Compound 4, half-maximal inhibitory concentration: 19.1 ug/mL
Estimate against measurement, compound 4: 1.4-fold (0.13 log units) below; the range from low to high includes it.
By their numbers in this assay, from the lowest: compounds 1, 2 and 4 (each within the scatter of the next, the first and the last beyond it); then compound 3.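

Thiophen-2-yl in place of 4-methoxy-3-methylphenyl gives a 3.6-fold lower number from compound 3 to compound 4 (0.55 log units; beyond the scatter), so a different single aromatic ring on the sulfonyl sulfur also lowers the number. Measured against phenyl, however, thiophen-2-yl gives a 2.1-fold higher number from compound 1 to compound 4 (0.32 log units; beyond the scatter), which shows that the two unsubstituted rings are not interchangeable at this position. Nothing available explains either step.

Still open, going by these compounds, is how a phenyl ring carrying only a methoxy group or only a methyl group would compare, which would separate the two additions in compound 3. Also open, on these data alone, is how a saturated ring such as cyclohexyl would behave on the sulfonyl sulfur with the core of compound 1.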